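This account rests on a few compounds, and the source may have more. Where it says the series, first, only, none or still open, it means among the compounds named here.

In a functional assay on the whole organism (blood, strain Sprague-Dawley albino) with Rattus norvegicus as the target, with stated times of 30 min and 24 h, at a dose of 100 mg/kg by the oral route (on this read-out lower numbers stand for less inhibition and higher numbers for more inhibition at the one dose given (going by the name of the read-out)), the following results were measured:

Compound 1 `COc1ccc(-c2cc(-c3ccccc3)no2)c(OCCCN2CCCCC2)c1`: 15%
Compound 2 `CCCCN(C)CCCOc1cc(OC)ccc1-c1cc(-c2ccccc2)no1`: 14.2%
Compound 3 `CCOC(=O)CCCOc1cc(OC)ccc1-c1cc(-c2ccccc2)no1`: "not determined" (no result reported)

Going by the values given here, compound 2 and compound 1 are the only two with a number in this assay; the gap between them, a number 0.8 percentage points lower from compound 1 to compound 2 (within the scatter), lies within the scatter, so the two cannot be told apart on this read-out, and compound 3 contributes no number. Compound 4 `CCN(CC)CC(O)COc1cc(OC)ccc1-c1cc(-c2ccccc2)no1` differs from compound 2 on a saturated chain carbon bound to an oxygen on an aromatic ring: 2-(diethylamino)-1-hydroxyethyl in place of 2-(butyl(methyl)amino)ethyl on a saturated chain carbon bound to an oxygen on an aromatic ring. Among the compounds with values here, the one measured step that bears on this change is the exchange of the amine on the chain, a number 0.8 percentage points lower from compound 1 to compound 2 (within the scatter), which stayed within the scatter. Within the data shown here, no measured pair speaks to the hydroxyl that enters with the 2-(diethylamino)-1-hydroxyethyl group, nor to the move from butyl(methyl)amino to diethylamino. On these grounds no shift beyond the scatter is expected in this assay, with the hydroxyl as the untested part. Compound 4 is therefore expected to give 14%, within 3% to 28%. The expected step of a number 0.2 percentage points lower from compound 2 to compound 4 (within the scatter) is estimated to stay within the scatter.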

Compound 4, a percentage reported as inhibition, in the whole organism at one dose (the size of the read-out at that dose, not a potency): 11.4%
Beside the measured number, compound 4's estimate is 2.6 percentage points above it, within the range that was stated.
By their numbers in this assay, from the lowest: compounds 4, 2 and 1 (each within the scatter of the next).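

In this assay, placing 2-(diethylamino)-1-hydroxyethyl on a saturated chain carbon bound to an oxygen on an aromatic ring gives a number 2.8 percentage points lower from compound 2 to compound 4 (within the scatter) when it replaces 2-(butyl(methyl)amino)ethyl and a number 3.6 percentage points lower from compound 1 to compound 4 (within the scatter) when it replaces 2-(piperidin-1-yl)ethyl. The earlier step exchanged only the amine, whereas these two also bring a hydroxyl onto the chain, and at this one dose neither step separates compound 4 from compound 2 or compound 1, so even a change that adds a hydrogen-bond donor gives no shift here that can be told from the scatter. No measurement is available to explain why these numbers lie so close together.

The compounds shown leave open what the hydroxyl and the diethylamino group each contribute alone, as they enter together in a single step. They also leave open whether a morpholine, a primary amine or a carboxylic acid at the end of the chain would move the number beyond the scatter.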